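The source may report more compounds than this note shows. Statements on the series, on what has been measured and on what is new or still open speak of the compounds shown alone.

Measured compounds and their values:
- compound 1, `CC(C)COc1cccc2occ(Cc3coc4ccccc4c3=O)c(=O)c12`: 1460 nM
- compound 2, `O=c1c(CCc2coc3ccccc3c2=O)coc2ccccc12`: > 10000 nM

Compound 1 carries the only number among the results shown; the one other value is a limit. In a functional assay on ACHN cells (Homo sapiens) for antiproliferative activity, read by XTT assay (a lower number here means a stronger inhibitor, a higher number a weaker inhibitor), compound 1 gives 1460 nM. Compound 2 is reported in this assay only as a limit, > 10000 nM, which is the limit of > 10000 nM in this assay, at which 1 of the 2 values shown sits. For the measured compounds named here, no step between two measured compounds that differ in one place is available, so nothing measured tells how large the change to be made is.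

Compound 3, `O=c1c(Cc2coc3ccccc3c2=O)coc2ccccc12`, is not yet measured. It differs from compound 1 by hydrogen in place of isobutoxy on an aromatic carbon. Going by the values given here, without a measured step of this kind, the direction rests on compound 1 as the sole number. A step toward a weaker inhibitor, beyond the usual scatter, is expected, a 3.4-fold higher number from compound 1 to compound 3 (0.53 log units; beyond the scatter). Compound 3 is estimated in this assay at 5000 nM, within a range from 1500 nM to 15000 nM.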

Compound 3, half-maximal inhibitory concentration: 510 nM
Compound 3: middle estimate off by 9.8-fold (0.99 log units), on the high side, and the stated range ends above it.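

Measured in this assay the replacement of isobutoxy by hydrogen on this aromatic carbon gives a 2.9-fold lower number from compound 1 to compound 3 (0.46 log units; beyond the scatter) and so moves toward a stronger inhibitor. For the compounds shown here, this is the first measured step at this position, and it shows that the isobutoxy group is not required here for antiproliferative activity, since compound 3 is the stronger inhibitor without it. Nothing in the data shown gives a cause for this step.

One step cannot tell whether this direction is particular to isobutoxy or holds for any group on this aromatic carbon. As far as these compounds go, a methoxy group, a longer chain, an amine or a carboxylic acid in the same place would be needed to tell these apart, and whether the step carries over to other positions on the shared core also remains open.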